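Swapping a benzyloxy arm for a carboxybutylamino arm

The source may report more compounds than this note shows. Statements on the series, on what has been measured and on what is new or still open speak of the compounds shown alone.

Measured compounds:
compound 1, `CCCCCCCCCCCCCCC(N)COCc1ccccc1`, 3000 nM
compound 2, `CCCCCCCCCCCCCCC(COCc1ccccc1)NC(=O)CCC(=O)O`, 30000 nM

Compound 1 and compound 2 were tested in a functional assay on Jurkat cells (Homo sapiens) for inhibition; on this read-out lower numbers stand for stronger inhibition and higher numbers for weaker inhibition. Of the two, compound 1 has the lower number. The step between them is a 10-fold higher number from compound 1 to compound 2 (1.00 log units; beyond the scatter). Compound 3, `CCCCCCCCCCCCCCC(N)CNCCCCC(=O)O`, has not been measured in this assay. Its difference from compound 1 is (4-carboxybutyl)amino in place of benzyloxy on a saturated chain carbon, two bonds along the chain from an amine nitrogen. Within the data shown here, the only measured step does not touch this position, and in compound 3 the amine nitrogen stays unchanged, so the step from compound 1 to compound 2 bears on it only loosely, as a sign that adding a carboxylic acid on this chain is not welcome. The account therefore expects a modest weakening, a 2.3-fold higher number from compound 1 to compound 3 (0.37 log units; beyond the scatter), for compound 3. Compound 3 is estimated at 7000 nM, within 1500 nM to 30000 nM.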

Compound 3, half-maximal inhibitory concentration: 55000 nM
The estimate for compound 3 lay 7.9-fold (0.90 log units) below the measured number; the measured number lies above the stated range.
By their numbers in this assay, from the lowest: compound 1; then compounds 2 and 3 (each within the scatter of the next).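

In this assay, putting (4-carboxybutyl)amino in place of benzyloxy on a saturated chain carbon, two bonds along the chain from an amine nitrogen, gives an 18-fold higher number from compound 1 to compound 3 (1.26 log units; beyond the scatter) and counts as a large loss. Among these compounds, this is the first reading at this position, and it shows that the benzyloxy arm cannot be exchanged for this one without that loss, even with the amine nitrogen unchanged. Nothing at hand explains the size of this step.

The exchange removes an aromatic ring and brings in both a carboxylic acid and a secondary amine, so the compounds shown do not separate these parts. A plain pentylamino arm, a methyl ester of the same arm or a benzylamino arm would each show which part carries the loss.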